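The source may report more compounds than this note shows. Statements on the series, on what has been measured and on what is new or still open speak of the compounds shown alone.

Compound 1 `COc1ccc(-c2cc(=O)c3cc(F)ccc3o2)cc1OC`: 83400 nM
Compound 2 `COc1ccc(-c2nc3cc(F)ccc3s2)cc1C`: 48 nM

In a functional assay on MCF7 cells (Homo sapiens) for inhibition (on this read-out lower numbers stand for stronger inhibition and higher numbers for weaker inhibition), compound 2 has the lower of the two numbers, at 48 nM, and compound 1 stands at 83400 nM. This gap lies far beyond the scatter. Compound 3 `COc1ccc(-c2nc3cc(F)ccc3s2)cc1Br` has bromo in place of methyl on an aromatic carbon, ortho to a methoxy group: bromo in place of methyl on an aromatic carbon. Among the compounds with values here, no measured pair isolates this single change, so the expectation is tentative. No shift beyond the scatter is expected in this assay, and the estimated step is a 1.2-fold lower number from compound 2 to compound 3 (0.08 log units; within the scatter). In this assay, the estimate for compound 3 is 40 nM, with an expected range of 6 nM to 300 nM.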

Compound 3, half-maximal inhibitory concentration: 850 nM
The estimate for compound 3 lay 21-fold (1.33 log units) below the measured number; measured number above the stated range.
By their numbers in this assay, from the lowest: compound 2; then compound 3; then compound 1.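

In this assay the aromatic carbon ortho to a methoxy group proved sensitive to its substituent: bromo in place of methyl gave an 18-fold higher number from compound 2 to compound 3 (1.25 log units; beyond the scatter) even though each group has only one heavy atom. Within the data shown here, this is the first comparison here that isolates a single change, and it favours methyl over bromo at this position. No supporting data bear on why the number rose. From the compounds shown here alone, whether chloro, ethyl or an amine on this carbon would give a number nearer that of compound 2 or compound 3 remains open.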